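Plasma protein binding across the urea series: compound 4

The compounds below may be only part of what the source reports. "The series", "measured", "known", "first", "only" and "open" are said of these compounds alone.

Measured so far:
compound 1 `CNc1nccc(N2CC[C@H](NC(=O)Nc3ccc(Cl)c(C(F)(F)F)c3)C2)n1`: 99.8%
compound 2 `CNc1nccc(N2CC[C@H](NC(=O)Nc3ccc(OC(F)(F)F)cc3)C2)n1`: 98.1%
compound 3 `CNc1nccc(N2CC[C@H](NC(=O)Nc3ccc(CN4CCN(C)CC4)c(C(F)(F)F)c3)C2)n1`: 85.8%

In an ADME assay on a cell-free system (plasma, Mus musculus) for protein binding, compound 2 holds the second highest of the three unbound fractions. Compound 3 sits above it with a higher unbound fraction, compound 1 below it with a lower one, and both gaps lie beyond the scatter, so compound 2 is placed between them rather than alongside either.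

Compound 4 `CNc1nccc(N2CC[C@H](NC(=O)Nc3ccc(OC)cc3)C2)n1` is the next step from compound 2. The change is methyl in place of trifluoromethyl on an oxygen on an aromatic ring, so the trifluoromethoxy of compound 2 becomes a methoxy on the same aromatic oxygen.

For the measured compounds named here, only one measured step exists, a 71-fold higher unbound fraction from compound 1 to compound 3 (1.85 log units; beyond the scatter), and it exchanges chloro for (4-methylpiperazin-1-yl)methyl on an aromatic carbon. Going by the values given here, that change is not the one taken here, and no measured pair exchanges trifluoromethyl for methyl on an aromatic oxygen. The step it does show is large, so the aryl end of the urea is a place where this assay moves. Without a matched precedent, a moderate shift is expected, toward a higher unbound fraction, a 3.2-fold higher unbound fraction from compound 2 to compound 4 (0.50 log units; beyond the scatter). For compound 4 the expected value is 94%, within 88% to 97.5%.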

Compound 4, plasma protein binding: 82.1%
Estimate against measurement, compound 4: 3.0-fold (0.47 log units) (unbound fraction) below; measured number outside the range, below it.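

In this assay, for the compounds shown here, the exchange of trifluoromethoxy for methoxy gives a 9.4-fold higher unbound fraction from compound 2 to compound 4 (0.97 log units; beyond the scatter), the first measured evidence that the substituent on this aromatic oxygen is itself a sensitive point. Going by these compounds alone, the only earlier step, a 71-fold higher unbound fraction from compound 1 to compound 3 (1.85 log units; beyond the scatter), brought in the much larger (4-methylpiperazin-1-yl)methyl group, so it could not show whether a compact exchange would register; here a step beyond the scatter comes from replacing trifluoromethyl with methyl, with neither group carrying a ring, a net charge, a hydrogen-bond donor or a hydrogen-bond acceptor. Nothing available explains why this exchange moves the read-out, so the step stands as an observation for this one matched pair only.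

Going by these compounds, whether difluoromethoxy or ethoxy on the same aromatic oxygen would sit with compound 2, with compound 4 or somewhere else in this assay remains open, as does the effect of a free hydroxyl at that place. Also open, on these data alone, is whether methyl in place of trifluoromethyl on an aromatic oxygen gives a step of similar size when the aromatic ring carries a further group, such as chloro.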